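Pyridin-2-yl for pyridin-3-yl in the amide series

A few compounds are considered here, and "the series" means these few. Any claim that something is new, unique, unknown or untested is made for them only; others in the source may bear on it.

In an ADME assay on HepG2 cells (Homo sapiens) for cytotoxicity, in the presence of a further agent that is not named here (on this read-out lower numbers stand for stronger inhibition and higher numbers for weaker inhibition), compound 1 (`Cn1c(Cc2ccccc2C(F)(F)F)nc(C(=O)NCc2cccnc2)c(O)c1=O`) gives > 100000 nM, which is a limit and not a number. Compound 2 (`COc1c(C(=O)NCc2ccccc2)nc(Cc2ccccc2C(F)(F)F)n(C)c1=O`) gives > 100000 nM, also a limit. The data so far therefore show only (the limit of > 100000 nM in this assay, at which 2 of the 2 values shown sit). Compound 3 (`Cn1c(Cc2ccccc2C(F)(F)F)nc(C(=O)NCc2ccccn2)c(O)c1=O`) differs from compound 1 by pyridin-2-yl in place of pyridin-3-yl on a saturated chain carbon bound to an amide-type nitrogen, with pyridin-2-yl in place of pyridin-3-yl on a saturated chain carbon bound to an amide-type nitrogen. Among the compounds with values here, no measured step covers this change. In this assay, nothing beyond the scatter is expected, and the estimated step is a number no higher from compound 1 to compound 3 (the limit leaves the size open). Compound 3 is expected at 100000 nM, with an estimated range of 50000 nM to 200000 nM.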

Compound 3, half-maximal inhibitory concentration: > 100000 nM
Compound 3: a limit, no number; the forecaster's own chance of this, stated with the estimate: 85%; the middle value lies on the limit itself.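

Compound 1 and compound 3 both sit at a limit, so no step can be read between them: the limit of > 100000 nM in this assay, at which 3 of the 3 values shown sit.

On these data alone, whether pyridin-2-yl and pyridin-3-yl differ at all in this assay stays open, as does any concentration at which these compounds inhibit.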